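Working notes: ester-bearing aryl in place of phenoxy

The source may hold more compounds than are shown below. What is called first, only, known or untested is meant among the compounds shown, and "the series" means these compounds.

Among the measured compounds shown here, compound 2 `Cc1ccccc1-n1nc(C)c2c1NC(=O)[C@H](C)S[C@@H]2c1ccc(Oc2ccccc2)cc1` gives 1300 nM in an assay on isolated protein for agonist activity at Bile acid receptor (Homo sapiens), read by AlphaScreen, with a stated time of 30 min (on this read-out higher numbers stand for an effect only at larger amounts of compound and lower numbers for an effect already at smaller amounts), the lowest of the two numbers measured so far; compound 1 `Cc1ccccc1-n1nc(C)c2c1NC(=O)[C@H](C)S[C@@H]2c1ccc(-c2ccoc2)cc1` gives 3500 nM in this assay, and the step of a 2.7-fold lower number from compound 1 to compound 2 (0.43 log units; beyond the scatter) came with phenoxy in place of furan-3-yl on an aromatic carbon. Compound 3 `COC(=O)c1ccc(-c2ccc([C@H]3S[C@@H](C)C(=O)Nc4c3c(C)nn4-c3ccccc3C)cc2)cc1` differs from compound 2 by 4-(methoxycarbonyl)phenyl in place of phenoxy on an aromatic carbon. For the measured compounds named here, only the one modest step bears on this change, and it concerns a different replacement, so no more than a small step in this assay is expected, estimated as a 1.3-fold lower number from compound 2 to compound 3 (0.11 log units; within the scatter). Compound 3 is expected at 1000 nM, within 300 nM to 4000 nM.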

Compound 3, half-maximal effective concentration: "not active" (no number reported)
Compound 3 has no reported number here; the estimate stays without a comparison.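

Among the compounds shown here, compound 3 is reported as "not active" in this assay without a number, so no step from compound 2 to compound 3 can be read. The compounds shown leave open how other aryl replacements of phenoxy would compare. No supporting data bear on this result.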